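The compounds below may be only part of what the source reports. "The series", "measured", "known", "first", "only" and "open" are said of these compounds alone.

Measured compounds:
- compound 1, `Brc1ccc2ccn(CCN3CCC4CCCCN4CC3)c2c1`, 71%
- compound 2, `CN1CCCN(CCn2ccc3cc(Br)ccc32)CC1`, 65%
- compound 3, `CN1CCCN(CCn2ccc3ccc(Cl)cc32)CC1`, 85%

These three compounds were tested in an assay on HEK293 cells for binding affinity to 5-hydroxytryptamine receptor 7 (Homo sapiens), read by radioligand binding, tested at 1 uM; a lower number here means less inhibition, a higher number more inhibition at the concentration tested (going by the name of the read-out). Compound 3 gives the highest of the three numbers. Its nearest neighbour is compound 1, whose number is lower by an amount beyond the usual scatter, and compound 2 lies further away, lower still and also beyond the scatter. For the measured compounds named here, no two of the measured compounds differ in a single place, so no single step between measured compounds can be read off.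

Compound 4, `CN1CCCN(CCn2ccc3ccc(C(N)=O)cc32)CC1`, has not yet been measured. It differs from compound 3 in one place: carbamoyl in place of chloro on an aromatic carbon. The change puts carbamoyl in place of chloro on an aromatic carbon. Going by the values given here, with no matching step among the measured compounds to lean on, the expectation rests on the change itself. A carbamoyl in place of chloro is expected to lower inhibition in this assay, by a step beyond the scatter, as a number 30 percentage points lower from compound 3 to compound 4 (beyond the scatter). Compound 4 is therefore estimated at 55%, with a range from 30% to 80%.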

Compound 4, a percentage reported as inhibition, at one concentration (the size of the read-out at that concentration, not a potency): 33%
Beside the measured number, compound 4's estimate is 22 percentage points above it; the range from low to high includes it.
By their numbers in this assay, from the lowest: compound 4; then compounds 2 and 1 (each within the scatter of the next); then compound 3.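

Putting carbamoyl in place of chloro on this aromatic carbon gives a number 52 percentage points lower from compound 3 to compound 4 (beyond the scatter) in this assay. For the compounds shown here, the earlier compounds offered no single-place step, so this is the first direct sign that the group on this carbon, with the rest of the molecule unchanged, can by itself shift inhibition by more than the usual scatter. Nothing available here accounts for the size of this step, and its cause remains unexplained.

Going by these compounds, with only chloro and carbamoyl compared at this position, it remains open whether a methoxy, a nitrile, a primary amine or a carboxylic acid there would give a number closer to compound 3 or to compound 4. On these data alone, it is also open whether the same exchange would produce a step of similar size on the core of compound 1.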